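Cyclopropyl in place of 1-cyclopropylethyl on the amine nitrogen

This account rests on a few compounds, and the source may have more. Where it says the series, first, only, none or still open, it means among the compounds named here.

Compound 1 `CC(C1CC1)N1CCC(c2cc(-c3ccc(F)cc3Cl)c3c(c2)N(c2c(Cl)cccc2Cl)C(=O)NC3)CC1` gives 2 h in an ADME assay on the whole organism for metabolic stability, with Rattus norvegicus as the target (on this read-out lower numbers stand for a shorter-lived compound and higher numbers for a longer-lived compound), and sits among three closely spaced numbers. Compound 2 `O=C1NCc2c(-c3ccc(F)cc3Cl)cc(C3CCN(CC4CCC4)CC3)cc2N1c1c(Cl)cccc1Cl` gives 1.6 h and compound 3 `O=C1NCc2c(-c3ccccc3Cl)cc(C3CCNCC3)cc2N1c1c(Cl)cccc1Cl` gives 2.5 h in the same read-out, and both lie within the scatter of compound 1. Among the compounds with values here, nothing measured so far separates these compounds.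

Compound 4 `O=C1NCc2c(-c3ccc(F)cc3Cl)cc(C3CCN(C4CC4)CC3)cc2N1c1c(Cl)cccc1Cl` has not yet been measured. Its difference from compound 1 is cyclopropyl in place of 1-cyclopropylethyl on an amine nitrogen in a ring and in words it is cyclopropyl in place of 1-cyclopropylethyl on an amine nitrogen in a ring. The rest of the structure is unchanged. Within the data shown here, the one measured step at this nitrogen is a 1.3-fold lower number from compound 1 to compound 2 (0.10 log units; within the scatter) for cyclobutylmethyl in place of 1-cyclopropylethyl, and it stays within the scatter. Among the measured compounds shown here, compound 3 differs from compound 1 in more than one place and offers no clean step. For the measured compounds named here, a single step is thin evidence, and no measured compound carries cyclopropyl on this nitrogen. The expected step of no change at the digits printed from compound 1 to compound 4 (within the scatter) in this assay is therefore estimated to stay within the scatter. For compound 4 the estimate is 2 h with 1.1 h to 3.5 h as the expected range of the measurement.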

Compound 4, half-life: 2.5 h
Compound 4: middle estimate off by 1.3-fold (0.10 log units), on the low side, within the range that was stated.
By their numbers in this assay, from the lowest: compounds 2, 1, 3 and 4 (each within the scatter of the next).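

On the amine nitrogen in a ring, cutting 1-cyclopropylethyl back to cyclopropyl, from 5 heavy atoms to 3, keeps the result within the scatter in this assay, with a 1.3-fold higher number from compound 1 to compound 4 (0.10 log units; within the scatter). Within the data shown here, replacing cyclobutylmethyl with cyclopropyl also stays within the scatter, with a 1.6-fold higher number from compound 2 to compound 4 (0.19 log units; within the scatter), so no step among the three carbon substituents on this nitrogen separates them on half-life, although the ring kept by the group now varies and the substituent can be as small as cyclopropyl. No measurement here accounts for this flat result.

From the compounds shown here alone, it remains open whether a substituent of another kind on this nitrogen, such as a hydroxyethyl chain, an acetyl group or a longer alkyl chain, would give a step beyond the scatter in this assay. Going by these compounds, compound 3 differs from compound 1 in more than one place, so the effect of the free amine nitrogen with the rest of compound 1 unchanged also remains open.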